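The source may report more compounds than this note shows. Statements on the series, on what has been measured and on what is new or still open speak of the compounds shown alone.

Measured so far in an assay on isolated protein for inhibition of tyrosine-protein kinase receptor UFO (Homo sapiens), with a stated time of 1.5 h; a lower number here means a stronger inhibitor, a higher number a weaker inhibitor:
- compound 1 `Cn1cc(-c2n[nH]c3ccc(-c4ccccc4)cc23)cn1`, giving 620 nM
- compound 2 `CN1CCC(CNc2ccc3[nH]nc(-c4cnn(C)c4)c3c2)CC1`, giving 1850000 nM

Compound 2 holds the highest of the two numbers; its nearest neighbour is compound 1, whose value is far lower, well beyond the scatter. Compound 1 carries a phenyl where compound 2 carries a substituted amino group, so the two differ in more than one respect and no single step can be read from them.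

Compound 3 `Cn1cc(-c2n[nH]c3ccc(NC4CCNC4)cc23)cn1` has not yet been measured. It differs from compound 2 in one place: pyrrolidin-3-yl in place of (1-methylpiperidin-4-yl)methyl on a nitrogen on an aromatic ring. The change keeps the nitrogen attached to the aromatic ring and exchanges the group on it for a smaller ring that brings a hydrogen-bond donor.

Within the data shown here, with no step between measured compounds to lean on, the direction is open. Compound 2 sits so high that a move down in this assay seems the more likely outcome, but a step either way within a moderate range, or none beyond the scatter, would not surprise. The estimate for compound 3 is 400000 nM, with a range from 50000 nM to 3000000 nM, which is expected to be a step of a 4.6-fold lower number from compound 2 to compound 3 (0.67 log units; beyond the scatter).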

Compound 3, half-maximal inhibitory concentration: 132000 nM
For compound 3 the middle estimate is 3.0-fold (0.48 log units) above the measured one; the measured number falls inside the stated range.
By their numbers in this assay, from the lowest: compound 1; then compound 3; then compound 2.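

In this assay, among these compounds, the group on a nitrogen on an aromatic ring proves able to move the number: pyrrolidin-3-yl in place of (1-methylpiperidin-4-yl)methyl gives a 14-fold lower number from compound 2 to compound 3 (1.15 log units; beyond the scatter) and so provides the first readable step at this position. The exchange at the aromatic carbon gives a 210-fold higher number from compound 1 to compound 3 (2.33 log units; beyond the scatter) with (pyrrolidin-3-yl)amino in place of phenyl, so the gain from the smaller ring leaves compound 3 far from compound 1 and the phenyl remains the better of these two groups at that place. No measurement at hand accounts for either step.

Among the compounds shown here, the single change to compound 3 alters the ring size, the methyl on the ring nitrogen, the methylene linking the ring and the count of hydrogen-bond donors together, so a 1-methylpyrrolidin-3-yl or a piperidin-4-yl on the same nitrogen would be needed to separate these contributions. Also open, from the compounds shown here alone, is whether a phenyl carrying an aminomethyl group would keep the number of compound 1 while adding an amine to that place.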